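A few compounds are considered here, and "the series" means these few. Any claim that something is new, unique, unknown or untested is made for them only; others in the source may bear on it.

In an ADME assay on BCBL1 cells (Homo sapiens) for cytotoxicity, with a stated time of 7 days (on this read-out lower numbers stand for higher toxicity in this test and higher numbers for lower toxicity in this test), compound 1 `Nc1nc(NC2CC2)c2ncn(/C=C3/CC3(CO)CO)c2n1` gives 71500 nM. Compound 2 `CCCNc1nc(N)nc2c1ncn2/C=C1/CC1(CO)CO` gives > 20000 nM, which is a limit of the assay and not a number. It is the limit of > 20000 nM in this assay, at which 1 of the 2 values shown sits, so compound 2 has a floor on the scale rather than a position.

Compound 3 `CC(C)Sc1nc(N)nc2c1ncn2/C=C1/CC1(CO)CO` differs from compound 2 in one place, with isopropylsulfanyl in place of propylamino on an aromatic carbon. Among the measured compounds shown here, only one measured step bears on this change, a step that the limit leaves unreadable from compound 1 to compound 2. It has no readable size, and it alters only the group carried on the nitrogen, whereas compound 3 loses that nitrogen altogether. For the measured compounds named here, no measured step shows what such an exchange does in this assay, so no size or direction can be carried over. The best remaining guide is compound 1 at 71500 nM, and compound 3 is expected to stay in that same high region, with low toxicity in this test. The expected change is a step that the limit leaves unreadable from compound 2 to compound 3, and its direction remains uncertain. The estimate for compound 3 is 35000 nM, with an expected range from 10000 nM to 100000 nM.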

Compound 3, half-maximal cytotoxic concentration: > 20000 nM
Compound 3: no number, only a limit (the forecaster's own chance of this, stated with the estimate: 55%); the middle value is on the limit's open side.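

In this assay compound 3 gives > 20000 nM, which is a limit of the assay and not a number, so no step from compound 1 or compound 2 to compound 3 can be read: the limit of > 20000 nM in this assay, at which 2 of the 3 values shown sit.

The compounds shown leave open where compound 2 and compound 3 lie on the scale, relative to each other and to compound 1.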